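A few compounds are considered here, and "the series" means these few. Any claim that something is new, unique, unknown or untested is made for them only; others in the source may bear on it.

Of the compounds shown here, three have so far been tested in an ADME assay on HeLa cells (Homo sapiens) for cytotoxicity, read by ATP content, with a stated time of 3 days; a higher number here means that more compound is tolerated, a lower number that less compound is tolerated. Compound 1 `CS(=O)(=O)CCCn1c(Cn2c(=O)n(C3CC3)c3ccncc32)cc2cc(Cl)ccc21` gives a reading of > 50000 nM in this assay, which is a limit of the measurement and not a number. Compound 3 `O=c1n(Cc2cc3ccncc3n2CCCCO)c2cnccc2n1C1CC1` gives > 100000 nM in this assay, again a limit. Compound 2 `N#CCCCn1c(Cn2c(=O)n(-c3ncco3)c3ccncc32)cc2cc(Cl)ccc21` stands at > 50000 nM in this assay, also a limit. So compound 2 sits where two of the three readings sit, at the limit of > 50000 nM in this assay, at which 2 of the 3 values shown sit, while the remaining reading sits at the limit of > 100000 nM in this assay, at which 1 of the 3 values shown sits. For the measured compounds named here, no two measured compounds differ in a single place, so no measured step shows how one change shifts the reading.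

Compound 4 `Cc1ccc(-n2c(=O)n(Cc3cc4cc(Cl)ccc4n3CCCC#N)c3cnccc32)cc1` has not yet been measured. It differs from compound 2 in one place: 4-methylphenyl in place of 1,3-oxazol-2-yl on an aromatic nitrogen. With every measured reading a limit, the change is expected to produce a step that the limit leaves unreadable from compound 2 to compound 4 in this assay, none beyond the scatter. Compound 4 is therefore expected to give about 60000 nM in this assay, within a range from 20000 nM to 150000 nM, and it is likely that only a limit is reported once more.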

Compound 4, half-maximal cytotoxic concentration: > 50000 nM
Compound 4: no number, only a limit; the forecaster's own chance of this, stated with the estimate: 80%; the middle value does not contradict the limit.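

Compound 2 and compound 4 each stand at a limit in this assay, not at a number, and the step between them, 4-methylphenyl in place of 1,3-oxazol-2-yl, cannot be read. The compounds shown leave open at what concentration any of them would become toxic to these cells, and whether this change shifts that concentration at all.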